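This account rests on a few compounds, and the source may have more. Where it says the series, first, only, none or still open, it means among the compounds named here.

Of the compounds shown here, two have so far been measured in a physicochemical assay for solubility, in phosphate buffer, with a stated time of 24 h, at pH 7.4, tested at 100 uM; on this read-out higher numbers stand for higher solubility and lower numbers for lower solubility. Compound 1 `O=C(NCc1ccc(S(=O)(=O)c2ccccc2)cc1)NCc1cccnc1` gives 10000 nM in this assay. Compound 2 `O=C(NCc1ccc(S(=O)(=O)C2CCOCC2)cc1)N1Cc2ccncc2C1` gives 206000 nM in this assay, the higher of the two numbers, and its gap from compound 1 lies beyond the usual scatter of repeated measurements. Compound 3 `O=C(NCc1ccc(S(=O)(=O)N2CCC[C@H](O)C2)cc1)N1Cc2ccncc2C1` has not yet been measured. It differs from compound 2 in one place: 3-hydroxypiperidin-1-yl in place of oxan-4-yl on a sulfonyl sulfur. Within the data shown here, no step between measured compounds shows how such a change plays out, so the expectation rests on compound 2 alone. The step is expected to be a modest rise in this assay, a 1.2-fold higher number from compound 2 to compound 3 (0.08 log units; within the scatter), though a result within the scatter of compound 2 would not surprise. Compound 3 is therefore estimated at 250000 nM in this assay, with a range from 100000 nM to 600000 nM.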

Compound 3, solubility: 215000 nM
Estimate against measurement, compound 3: 1.2-fold (0.07 log units) above, and the stated range covers the measured number.
By their numbers in this assay, from the lowest: compound 1; then compounds 2 and 3 (each within the scatter of the next).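

In this assay, putting 3-hydroxypiperidin-1-yl in place of oxan-4-yl on a sulfonyl sulfur gives a 1.0-fold higher number from compound 2 to compound 3 (0.02 log units; within the scatter), so this read-out does not separate the two compounds. Among these compounds, this is the first single-place change seen at this position, and it shows that a group bringing a hydrogen-bond donor and a defined stereocentre can stand there with no shift beyond the scatter. No supporting data bear on why the two groups read alike.

Still open, from the compounds shown here alone, is whether the mirror-image form of 3-hydroxypiperidin-1-yl, a piperazin-1-yl group or a group carrying a carboxylic acid would read the same on this sulfonyl sulfur. Compound 1 differs from compound 2 and compound 3 in more than one place, so its gap from them cannot be assigned to any single group.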